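This account rests on a few compounds, and the source may have more. Where it says the series, first, only, none or still open, it means among the compounds named here.

Compound 1 `CN(C)CCn1cnnc1-c1cc(Oc2ccc(NC(=O)N/N=C/c3c(Cl)cccc3Cl)cc2F)ccn1` carries a 2,6-dichlorophenyl group on a carbon with a double bond to nitrogen. In a functional assay on U-87MG ATCC cells (Homo sapiens) for cytotoxicity, read by MTT assay, with a stated time of 72 h (on this read-out lower numbers stand for stronger inhibition and higher numbers for weaker inhibition), compound 1 gives only a limit, > 100000 nM, so its true number is not known. Going by the values given here, two neighbours that keep the shared core and change only this group have been measured. Compound 2 `CN(C)CCn1cnnc1-c1cc(Oc2ccc(NC(=O)N/N=C/c3c[nH]c4ccccc34)cc2F)ccn1` gives 690 nM in this assay. Compound 3 `COc1ccc(/C=N/NC(=O)Nc2ccc(Oc3ccnc(-c4nncn4CCN(C)C)c3)c(F)c2)c(OC)c1OC` gives 7650 nM in this assay. The step of an at least 140-fold lower number from compound 1 to compound 2 (2.16 log units; beyond the scatter) and the step of an at least 13-fold lower number from compound 1 to compound 3 (1.11 log units; beyond the scatter) both show that leaving the 2,6-dichlorophenyl group brings a far lower number; the step of an 11-fold higher number from compound 2 to compound 3 (1.04 log units; beyond the scatter) shows that what enters matters too. Compound 4 `CN(C)CCn1cnnc1-c1cc(Oc2ccc(NC(=O)N/N=C/c3ccc(O)c(O)c3)cc2F)ccn1` is not yet measured. It differs from compound 1 in one place: 3,4-dihydroxyphenyl in place of 2,6-dichlorophenyl on a carbon with a double bond to nitrogen. Among the compounds with values here, the 3,4-dihydroxyphenyl group is neither the 1H-indol-3-yl of compound 2 nor the 2,3,4-trimethoxyphenyl of compound 3, and no measured step covers it directly. Because the steps of an at least 140-fold lower number from compound 1 to compound 2 (2.16 log units; beyond the scatter) and an at least 13-fold lower number from compound 1 to compound 3 (1.11 log units; beyond the scatter) both ran well beyond the scatter toward lower numbers, a lowering is expected for compound 4 too, of a size between those two steps: an at least 20-fold lower number from compound 1 to compound 4 (1.30 log units; beyond the scatter). Compound 4 is therefore expected to give about 5000 nM in this assay, with a range from 1000 nM to 50000 nM.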

Compound 4, half-maximal inhibitory concentration: > 100000 nM
Compound 4 gave a limit, no number; the forecaster's own chance of this, stated with the estimate: 20%; at least 20-fold (1.30 log units) between middle value and limit.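

Putting a new group on this carbon does not by itself lower the number: with 3,4-dihydroxyphenyl in place of 2,6-dichlorophenyl, compound 4 gives only a limit in this assay, so the lowering seen with compound 2 and compound 3 is not shared by every replacement. A six-membered aromatic ring of carbon that bears oxygen-containing groups is also not enough for a measurable number, as the two neighbours show through an at least 13-fold higher number from compound 3 to compound 4 (1.11 log units; beyond the scatter) and an at least 140-fold higher number from compound 2 to compound 4 (2.16 log units; beyond the scatter). The step from compound 1 to compound 4 cannot be read, because both ends of it are limits and not numbers: the limit of > 100000 nM in this assay, at which 2 of the 4 values shown sit.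

The compounds shown leave open whether compound 4 differs from compound 3 through its hydroxy groups or through the pattern of groups on the ring, a question that a 3,4-dimethoxyphenyl group on this carbon would help to separate. They also leave open how far compound 1 and compound 4 truly lie apart, and whether the ring hydrogen on nitrogen in compound 2 counts, which a 1-methylindol-3-yl group would test.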